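Compound 3: 1-methylcyclohexyl in place of tert-butyl

The source may report more compounds than this note shows. Statements on the series, on what has been measured and on what is new or still open speak of the compounds shown alone.

Compound 1 (`CCC[C@H](NC(=O)[C@@H]1[C@H]2[C@@H](CN1C(=O)[C@@H](NC(=O)NC1([C@H]3CCCCS3(=O)=O)CCCCC1)C(C)(C)C)C2(C)C)C(=O)C(=O)NC1CC1`) gives 138 ng.h/mL in an ADME assay on the whole organism (plasma) for pharmacokinetics, with Rattus norvegicus as the target, with a stated time of 24 h, at a dose of 10 mg/kg by the oral route (on this read-out higher numbers stand for higher exposure at the dose given and lower numbers for lower exposure), and compound 2 (`CCC[C@H](NC(=O)[C@@H]1[C@H]2[C@@H](CN1C(=O)[C@@H](NC(=O)NC1([C@H]3CCCS3(=O)=O)CCCCC1)C(C)(C)C)C2(C)C)C(=O)C(=O)NC1CC1`) gives 203 ng.h/mL within the scatter of compound 1, so compound 1 holds no separate place in this pair.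

Compound 3 (`CCC[C@H](NC(=O)[C@@H]1[C@H]2[C@@H](CN1C(=O)[C@@H](NC(=O)NC1([C@H]3CCCCS3(=O)=O)CCCCC1)C1(C)CCCCC1)C2(C)C)C(=O)C(=O)NC1CC1`) has not been measured. It keeps the core of compound 1 and differs by one change (1-methylcyclohexyl in place of tert-butyl on a saturated chain carbon bound to an amide-type nitrogen and a carbonyl carbon) on a saturated chain carbon bound to an amide-type nitrogen and a carbonyl carbon.

For the measured compounds named here, the only measured step (a 1.5-fold higher number from compound 1 to compound 2 (0.17 log units; within the scatter)) lies at another place, with 1,1-dioxothiolan-2-yl in place of 1,1-dioxothian-2-yl on a saturated ring carbon, and it stays within the scatter. Going by the values given here, no measured step touches the place changed in compound 3, so the data give neither a size nor a direction for this change. No step beyond the scatter is therefore expected in this assay, and the uncertainty stays wide. The expected step (a 1.1-fold lower number from compound 1 to compound 3 (0.03 log units; within the scatter)) is an estimate only. For compound 3 the estimated value is 130 ng.h/mL (expected range 40 ng.h/mL to 420 ng.h/mL).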

Compound 3, area under the concentration-time curve: 586 ng.h/mL
For compound 3 the middle estimate is 4.5-fold (0.65 log units) below the measured one; measured number above the stated range.
By their numbers in this assay, from the lowest: compounds 1 and 2 (each within the scatter of the next); then compound 3.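

In this assay, for the compounds shown here, the saturated chain carbon bound to an amide-type nitrogen and a carbonyl carbon is the first place where a single change goes beyond the scatter: 1-methylcyclohexyl in place of tert-butyl gives a 4.2-fold higher number from compound 1 to compound 3 (0.63 log units; beyond the scatter) and so marks this place as one that matters for this read-out, whereas the earlier step at the other place (a 1.5-fold higher number from compound 1 to compound 2 (0.17 log units; within the scatter)) stayed within the scatter. The entering group is all carbon and brings one six-membered non-aromatic ring, so a step of this size at this place required no added hydrogen-bond donor or acceptor and no net charge. Nothing in the data at hand accounts for the step, which stands as an observation only.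

On these data alone, one step cannot separate the contribution of the ring from that of the added carbon count, so it remains open how cyclohexyl, 1-methylcyclopentyl or 1-methylcycloheptyl would read at this place. Also open, as far as these compounds go, is whether the same exchange carries over to compound 2, with its 1,1-dioxothiolan-2-yl group, and whether a group bearing an amine or a carboxylic acid would be tolerated here.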